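Methylsulfanyl for chloro on a fused quinone core

The source may hold more compounds than are shown below. What is called first, only, known or untested is meant among the compounds shown, and "the series" means these compounds.

Measured so far:
compound 1, `CNC1=C(Cl)C(=O)c2cccnc2C1=O`, 5210 nM
compound 2, `NC1=C(Cl)C(=O)c2ncccc2C1=O`, 2040 nM
compound 3, `CSC1=C(N)C(=O)c2cccnc2C1=O`, 8320 nM

All three were tested in an ADME assay on cells (T-cell, Homo sapiens) for antiproliferative activity, read by MTT assay, with a stated time of 48 h; a lower number here means a stronger inhibitor, a higher number a weaker inhibitor. Compound 2 gives the lowest number of the three; compound 1 and compound 3 lie within the usual scatter of each other, so no order between those two is claimed. The difference between the core of compound 1 and the core of compound 2 is not broken down here.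

One structural change recurs. From compound 2 to compound 3 it is methylsulfanyl in place of chloro on a double-bonded ring carbon, and it brought a 4.1-fold higher number from compound 2 to compound 3 (0.61 log units; beyond the scatter). The unmeasured compound 4, `CNC1=C(SC)C(=O)c2cccnc2C1=O`, carries the same kind of change relative to compound 1: methylsulfanyl in place of chloro on a double-bonded ring carbon. It is not the same change, since around the place the ring atom bears a methylamino group (2 heavy atoms) in compound 1 but an amino group (1 heavy atom) in compound 2. No other pair among these compounds shows this replacement, so the expectation rests on a single precedent.

For compound 4 in this assay the step expected is a 3.3-fold higher number from compound 1 to compound 4 (0.51 log units; beyond the scatter), set somewhat smaller than the measured one because a 4.1-fold higher number from compound 2 to compound 3 (0.61 log units; beyond the scatter) comes from a different amine substituent and a single pair. Compound 4 is expected to give about 17000 nM, in a range from 6000 nM to 50000 nM.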

Compound 4, half-maximal inhibitory concentration: 7570 nM
Beside the measured number, compound 4's estimate is 2.2-fold (0.35 log units) above it; measured number inside the range.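

In this assay, methylsulfanyl in place of chloro on the core of compound 1 gives a 1.5-fold higher number from compound 1 to compound 4 (0.16 log units; within the scatter), so on this core the replacement has no effect that can be read above the scatter. For the compounds shown here, the size of the step does not carry over between the two cores: the same change on two cores in this assay, a 4.1-fold higher number (0.61 log units; beyond the scatter) from compound 2 to compound 3 and a 1.5-fold higher number (0.16 log units; within the scatter) from compound 1 to compound 4, 2.8-fold (0.45 log units) apart, beyond the scatter of two such steps These two pairs show only that a single precedent was a poor guide to step size here; they do not show whether the methylamino group in place of the amino group or some other feature of the two cores accounts for the gap, and they offer no rule for a further core.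

The compounds shown leave open how the replacement behaves with a longer chain on the amine, such as ethylamino or benzylamino, and whether ethylsulfanyl or methoxy in place of chloro would follow methylsulfanyl in this assay. Also open, from the compounds shown here alone, is how the step reads on a matched set in which methylamino and amino groups sit on one identical core, which would separate the amine from the rest of the core.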